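A few compounds are considered here, and "the series" means these few. Any claim that something is new, unique, unknown or untested is made for them only; others in the source may bear on it.

The study measured three compounds in an assay on isolated protein for displacement of a labelled ligand from Alpha-1A adrenergic receptor (Homo sapiens); a higher number here means a weaker inhibitor, a lower number a stronger inhibitor. Compound 1 `O=C(NCCCCN1CCN(c2ccccc2Cl)CC1)c1ccc2ccccc2c1` gives 29.9 nM in this assay, the lowest of the three numbers shown. Compound 3 `COc1ccccc1N1CCN(CCCCNC(=O)N(C)c2ccccc2)CC1` gives 116 nM in this assay, which lies beyond the usual scatter from compound 1, and compound 2 `CCOC(=O)Nc1cccc(N2CCN(CCCCNC(=O)c3ccc4ccccc4c3)CC2)c1` gives 1030 nM in this assay, the furthest of the three from compound 1. Compound 1 is thus the strongest binder among the three measured compounds.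

Compound 4 `Cc1cccc(N2CCN(CCCCNC(=O)c3ccc4ccccc4c3)CC2)c1C` has not yet been measured. It differs from compound 1 in one place: 2,3-dimethylphenyl in place of 2-chlorophenyl on an amine nitrogen in a ring. The rest of the shared core, including the naphthalene amide and the four-carbon chain, is unchanged.

Going by the values given here, no measured pair in this set isolates the exchange of a 2-chlorophenyl for a 2,3-dimethylphenyl on the amine nitrogen in the ring, so the direction of the step can only be expected, not read from the data. The expectation is a step of a 1.5-fold lower number from compound 1 to compound 4 (0.17 log units; within the scatter) from compound 1 to compound 4 in this assay, a change that may stay within the usual scatter or slightly favour compound 4. Compound 4 is therefore expected to give about 20 nM in this assay, within a range from 6 nM to 70 nM.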

Compound 4, inhibition constant: 230 nM
The estimate for compound 4 lay 12-fold (1.06 log units) below the measured number; measured number above the stated range.
By their numbers in this assay, from the lowest: compound 1; then compounds 3 and 4 (each within the scatter of the next); then compound 2.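

In this assay, the exchange of 2-chlorophenyl for 2,3-dimethylphenyl on the amine nitrogen in the ring gives a 7.7-fold higher number from compound 1 to compound 4 (0.89 log units; beyond the scatter), with the naphthalene amide and the four-carbon chain unchanged. Going by these compounds alone, this is the first step in the set that can be read, and it shows that binding responds to the group at this position even when the rest of the core stays the same: here, the 2,3-dimethylphenyl group gives the weaker binder. No measurement shown bears on why the number rises.

The compounds leave open whether the step follows from losing the chlorine or from gaining either of the two methyl groups, a question that a phenyl ring with no substituent, or one carrying a single methyl or a single fluorine, on the same nitrogen could help to separate. They also leave open whether the same exchange would give a step of similar size with a longer chain, or with a urea in place of the naphthalene amide.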